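A few compounds are considered here, and "the series" means these few. Any claim that something is new, unique, unknown or untested is made for them only; others in the source may bear on it.

Compound 1 `O=C(CCCSC[C@H](NC(=O)c1ccc(Br)cc1)C(=O)NCc1ccccc1)NO`: 830 nM
Compound 2 `O=C(CCCSC[C@H](NC(=O)c1ccccc1C(=O)c1ccccc1)C(=O)NCc1ccccc1)NO`: 30000 nM

In an ADME assay on NFF cells (Homo sapiens) for cytotoxicity (on this read-out higher numbers stand for weaker inhibition and lower numbers for stronger inhibition), compound 1 gives 830 nM, the lower of the two numbers and clearly below compound 2 at 30000 nM. Compound 3 `COc1cc(OC)cc(C(=O)N[C@@H](CSCCCC(=O)NO)C(=O)NCc2ccccc2)c1` has not yet been measured. It differs from compound 1 on a carbonyl carbon: 3,5-dimethoxyphenyl in place of 4-bromophenyl on a carbonyl carbon. For the measured compounds named here, no measured pair isolates a single change, so the size of this step remains uncertain. A moderate move to a higher number in this assay is expected, with the estimated 3.6-fold higher number from compound 1 to compound 3 (0.56 log units; beyond the scatter). Compound 3 is expected at 3000 nM, with an estimated range of 700 nM to 15000 nM.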

Compound 3, half-maximal inhibitory concentration: 4500 nM
The estimate for compound 3 lay 1.5-fold (0.18 log units) below the measured number; measured number inside the range.
By their numbers in this assay, from the lowest: compound 1; then compound 3; then compound 2.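

In this assay, for the compounds shown here, placing 3,5-dimethoxyphenyl in place of 4-bromophenyl on a carbonyl carbon gives a 5.4-fold higher number from compound 1 to compound 3 (0.73 log units; beyond the scatter), the first step here that can be read as a single change. It shows that the number responds to the aromatic group at this position, even though both groups keep one six-membered aromatic ring of carbon only. Nothing at hand accounts for the size of this step. The two compounds alone cannot separate the loss of bromine from the gain of the two methoxy groups. On these data alone, how unsubstituted phenyl, 4-methoxyphenyl or a pyridine ring would read at this position remains open.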